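Cyclic Tertiary Amide in Place of a Secondary Cyclohexyl Amide

The source may hold more compounds than are shown below. What is called first, only, known or untested is meant among the compounds shown, and "the series" means these compounds.

Measured compounds:
Compound 1, `CCN(CC)S(=O)(=O)c1ccc(S(=O)(=O)N2CCC[C@@H](C(=O)N[C@H]3CC[C@H](OC)CC3)C2)cc1` — 2290 nM
Compound 2, `CCN(CC)S(=O)(=O)c1ccc(S(=O)(=O)N2CCC[C@@H](C(=O)N3CCC(OC)CC3)C2)cc1` — 50 nM
Compound 3, `CCN(CC)S(=O)(=O)c1ccc(S(=O)(=O)N2CCC[C@@H](C(=O)N[C@H]3CCOC3)C2)cc1` — 290 nM

In a functional assay on MIA PaCa-2 cells (Homo sapiens) for inhibition, read by MTT assay, with a stated time of 3 days (a higher number here means a weaker inhibitor, a lower number a stronger inhibitor), compound 1 gives 2290 nM and stands with the highest number of the three. Its nearest neighbour is compound 3, at 290 nM, and the furthest is compound 2, at 50 nM. Both steps from compound 1 lie beyond the scatter: a 46-fold lower number from compound 1 to compound 2 (1.66 log units; beyond the scatter) and a 7.9-fold lower number from compound 1 to compound 3 (0.90 log units; beyond the scatter).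

Compound 4, `CCN(CC)S(=O)(=O)c1ccc(S(=O)(=O)N2CCC[C@@H](C(=O)N3CCS(=O)(=O)CC3)C2)cc1`, has not yet been measured. It differs from compound 1 in one place: 1,1-dioxothiomorpholin-4-yl in place of (4-methoxycyclohexyl)amino on a carbonyl carbon. For the measured compounds named here, the change most like it among the measured steps is the one from compound 1 to compound 2, where the secondary amide was also replaced by a ring closed onto the amide-type nitrogen, and that step was large: a 46-fold lower number from compound 1 to compound 2 (1.66 log units; beyond the scatter). The step of a 5.8-fold higher number from compound 2 to compound 3 (0.76 log units; beyond the scatter) shows that the group carried on the ring also matters, so the full extent of that gain is not assured for the sulfone-bearing ring.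

The expected step is therefore a lower number, a 15-fold lower number from compound 1 to compound 4 (1.18 log units; beyond the scatter), with compound 4 estimated at 150 nM, in a range from 40 nM to 600 nM.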

Compound 4, half-maximal inhibitory concentration: 220 nM
Compound 4: middle estimate off by 1.5-fold (0.17 log units), on the low side; the measured number falls inside the stated range.
By their numbers in this assay, from the lowest: compound 2; then compounds 4 and 3 (each within the scatter of the next); then compound 1.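

In this assay, the lower number seen with 4-methoxypiperidin-1-yl is not unique to that group on this carbonyl carbon, since 1,1-dioxothiomorpholin-4-yl also gives a 10-fold lower number from compound 1 to compound 4 (1.02 log units; beyond the scatter). The ring on the amide-type nitrogen does not settle the outcome by itself, as the two ring amides remain apart, with a 4.4-fold higher number from compound 2 to compound 4 (0.64 log units; beyond the scatter). Losing the amide hydrogen is not enough to set the number either: compound 3 keeps that hydrogen, yet it cannot be told apart from compound 4 in this assay, with a 1.3-fold lower number from compound 3 to compound 4 (0.12 log units; within the scatter).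

Nothing shown accounts for these differences. On these data alone, how a morpholin-4-yl group, or a piperidin-1-yl ring bearing a carboxylic acid, would behave on this carbonyl carbon stays open.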